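Sulfonyl side chain exchange, compound 1 to compound 3

The source may hold more compounds than are shown below. What is called first, only, known or untested is meant among the compounds shown, and "the series" means these compounds.

Measured in an ADME assay on CHO cells (Cricetulus griseus) for cytotoxicity, read by MTT assay; on this read-out lower numbers stand for stronger inhibition and higher numbers for weaker inhibition:
- compound 1 `O=S(=O)(NCC1COC1)c1cccc(-c2ccc3nccc(-c4ccncc4)c3n2)c1`: 16000 nM
- compound 2 `CS(=O)(=O)c1cccc(Nc2ccc3nccc(-c4ccncc4)c3n2)c1`: > 50000 nM

The entry for compound 2 is a limit of the assay, not a number. Within the data shown here, compound 1 therefore holds the only numeric value in this small set.

Compound 3 `O=S(=O)(CCO)c1cccc(-c2ccc3nccc(-c4ccncc4)c3n2)c1` has not yet been measured. It carries 2-hydroxyethyl in place of ((oxetan-3-yl)methyl)amino on a sulfonyl sulfur. Among the measured compounds shown here, no measured step covers this change. The expectation rests only on compound 1 at 16000 nM, with no shift beyond the scatter expected in this assay. The expected step is small: a 1.3-fold higher number from compound 1 to compound 3 (0.10 log units; within the scatter). The estimated value for compound 3 is 20000 nM, with an expected range of 6000 nM to 50000 nM.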

Compound 3, half-maximal inhibitory concentration: 26000 nM
For compound 3 the middle estimate is 1.3-fold (0.11 log units) below the measured one, and the stated range covers the measured number.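

In this assay, 2-hydroxyethyl in place of ((oxetan-3-yl)methyl)amino on a sulfonyl sulfur gives a 1.6-fold higher number from compound 1 to compound 3 (0.21 log units; within the scatter). In this pair, the read-out therefore does not depend on the four-membered non-aromatic ring or on the nitrogen: (2-hydroxyethyl)sulfonyl and ((oxetan-3-yl)methyl)sulfamoyl cannot be told apart here.

Going by these compounds, whether a basic amine, a carboxylic acid or a longer chain on the same sulfonyl sulfur would move the number beyond the scatter remains open. Compound 2 is a limit of the assay, not a number, and differs from compound 3 in more than one place, so it adds nothing on this change: the limit of > 50000 nM in this assay, at which 1 of the 3 values shown sits.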